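The compounds below may be only part of what the source reports. "The series", "measured", "known", "first", "only" and "open" are said of these compounds alone.

Measured compounds in a functional assay on SMMC-7721 cells (Homo sapiens) for inhibition, read by CCK-8 assay, with a stated time of 72 h, tested at 8 uM; a lower number here means less inhibition of growth, a higher number more inhibition of growth at the concentration tested:
compound 1, `COc1ccc(SCc2ccc(/C=C/C(=O)Nc3ccccc3N)cc2)cc1OC`, gives 44.6%;
compound 2, `Nc1ccccc1NC(=O)c1ccc(CSc2ccc(C(F)(F)F)cn2)cc1`, gives 7.57%;
compound 3, `Cc1ccc(SCc2ccc(C(=O)Nc3ccccc3N)cc2)cc1`, gives 82.7%.

Compound 1 stands second highest of the three in this assay: its gap to compound 2 lies beyond the scatter, and so does its larger gap to compound 3. Among the compounds with values here, no two measured compounds differ in one place only, so no single step is isolated within the set.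

Compound 4, `Nc1ccccc1NC(=O)/C=C/c1ccc(CSc2cccc(F)c2)cc1`, is not yet measured. It differs from compound 1 by 3-fluorophenyl in place of 3,4-dimethoxyphenyl on a sulfur.

Within the data shown here, with no comparable step among the measured compounds, the expectation for the move from compound 1 to compound 4 in this assay is a modest change only, likely within or near the scatter, estimated as a number 5.4 percentage points higher from compound 1 to compound 4 (within the scatter). Compound 4 is thus expected to give about 50% in this assay, with a range from 25% to 75%.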

Compound 4, percent growth inhibition at one concentration: 8.25%
The estimate for compound 4 lay 41.8 percentage points above the measured number; the whole stated range lies above it.
By their numbers in this assay, from the lowest: compounds 2 and 4 (each within the scatter of the next); then compound 1; then compound 3.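

In this assay, within the data shown here, 3-fluorophenyl in place of 3,4-dimethoxyphenyl on a sulfur gives a number 36.4 percentage points lower from compound 1 to compound 4 (beyond the scatter), the only single change that can be read so far. It shows that growth inhibition at the concentration tested depends strongly on the aromatic group carried on this sulfur. No measurement at hand accounts for the drop.

Still open, going by these compounds, is whether the drop follows the loss of the methoxy groups or the entry of fluorine. An unsubstituted phenyl or a 3-methoxyphenyl on the same sulfur would help to separate the two.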